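Primary amide in place of the oxanylethyl amide

The source may hold more compounds than are shown below. What is called first, only, known or untested is meant among the compounds shown, and "the series" means these compounds.

The series shares one core, carrying a methylamide and a benzyl or oxanylmethyl substituent. Compound 1 `CNC(=O)c1cc(C(=O)NCCC2CCOCC2)cn(Cc2ccccc2)c1=O` is the more lipophilic of the two measured compounds: in a physicochemical assay for lipophilicity, at pH 7.4 (on this read-out lower numbers stand for lower lipophilicity and higher numbers for higher lipophilicity), compound 1 gives 3.6, the highest of the two numbers recorded. Within the data shown here, compound 2 `CNC(=O)c1cc(C(=O)NC2CC2)cn(CC2CCOCC2)c1=O` gives 1.5 in this assay, a number that lies far below that of compound 1, well beyond the usual scatter; the two compounds differ in more than one place, so no single step between them is drawn.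

Compound 3 `CNC(=O)c1cc(C(N)=O)cn(Cc2ccccc2)c1=O` has not yet been measured. Against compound 1 the change is hydrogen in place of 2-(oxan-4-yl)ethyl on an amide-type nitrogen. The group that leaves is a chain with a six-membered non-aromatic ring and one hydrogen-bond acceptor; what remains is a bare amino group on the carbonyl.

A sizeable downward step in this assay is expected, larger than the scatter, as the expected step from compound 1 to compound 3 is a number 1.60 log units lower from compound 1 to compound 3 (beyond the scatter). Compound 3 is therefore estimated at 2 in this assay, within the expected range of 1.4 to 2.6.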

Compound 3, distribution coefficient: 2
Compound 3: middle estimate and measured number agree at the digits printed, within the range that was stated.
By their numbers in this assay, from the lowest: compound 2; then compound 3; then compound 1.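

In this assay, among these compounds, hydrogen in place of 2-(oxan-4-yl)ethyl on an amide-type nitrogen gives a number 1.60 log units lower from compound 1 to compound 3 (beyond the scatter), the first step that can be read at a single place. The read-out at this nitrogen is thus shown to move by a large amount with the benzyl group and the methylamide unchanged, which the gap between the two earlier compounds could not show, as they differ in more than one place. No measurement shown here accounts for the size of this step.

With a single step, the share of the ethyl chain and the share of the oxane ring in the change cannot be separated; a plain 2-cyclohexylethyl chain, an oxan-4-yl group directly on the nitrogen, or a small methyl group at the same place would divide it. Also open, from the compounds shown here alone, are a basic amine or a carboxylic acid at the end of the chain, and whether the same change gives a step of similar size with oxanylmethyl in place of benzyl on the shared core.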